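Efficacy at the bile acid receptor: from compound 1 to compound 4

The source may hold more compounds than are shown below. What is called first, only, known or untested is meant among the compounds shown, and "the series" means these compounds.

Measured compounds:
compound 1, `CCOc1cccc(-c2ccc([C@H]3S[C@@H](C)C(=O)Nc4c3c(C)nn4-c3ccccc3C)cc2)c1`: 13%
compound 2, `COc1ccccc1-n1nc(C)c2c1NC(=O)[C@H](C)S[C@@H]2c1ccc(Oc2ccccc2)cc1`: 37%
compound 3, `Cc1ccc(-n2nc(C)c3c2NC(=O)[C@H](C)S[C@@H]3c2ccc(Oc3ccccc3)cc2)cc1`: 11%

In an assay on isolated protein for agonist activity at Bile acid receptor (Homo sapiens), read by AlphaScreen, with a stated time of 30 min (a higher number here means a larger maximal response, a lower number a smaller maximal response), compound 1 gives 13%, the second highest of the three numbers. Compound 3 gives 11%, within the scatter of compound 1. Compound 2 gives 37%, beyond the scatter above compound 1. Among the compounds with values here, the one step between compounds that differ in a single place is a number 26 percentage points lower from compound 2 to compound 3 (beyond the scatter); it concerns the group on the aromatic nitrogen, which compound 1 and compound 4 share, so it does not bear directly on the change considered here.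

Compound 4, `COc1ccc(Oc2ccc([C@H]3S[C@@H](C)C(=O)Nc4c3c(C)nn4-c3ccccc3C)cc2)cc1`, is the unmeasured compound. It differs from compound 1 as follows: 4-methoxyphenoxy in place of 3-ethoxyphenyl on an aromatic carbon. Within the data shown here, no measured pair isolates this exchange. Compound 3 carries a phenoxy at the same place and sits within the scatter of compound 1, which gives no sign of a large effect from a group of this kind. The expected step is therefore a number 5 percentage points higher from compound 1 to compound 4 (within the scatter), none beyond the scatter. Compound 4 is estimated at 18%, with a range from 5% to 40%.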

Compound 4, largest response reached (reported as efficacy), in percent of the reference or control that the assay uses: 70%
Compound 4: the middle estimate sits 52 percentage points below what was measured, outside the stated range (above it).
By their numbers in this assay, from the lowest: compounds 3 and 1 (each within the scatter of the next); then compound 2; then compound 4.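

With the shared core held fixed, the exchange of 3-ethoxyphenyl for 4-methoxyphenoxy gives a number 57 percentage points higher from compound 1 to compound 4 (beyond the scatter) in this assay and shows that the response is highly sensitive to the group at this place on the aromatic carbon, para to a large group. The two groups have the same count of 9 heavy atoms and each has one six-membered aromatic ring of carbon only, yet the entering group has 2 hydrogen-bond acceptors against 1, so the large step comes without any change in those heavy-atom or ring counts. No evidence is available to explain this step.

The exchange alters the link through oxygen and the alkoxy group together, so the compounds shown do not tell which change carries the step. Going by these compounds, whether an amine or a carboxylic acid in place of the methoxy would keep this response also remains open.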